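The source may report more compounds than this note shows. Statements on the series, on what has been measured and on what is new or still open speak of the compounds shown alone.

The measured compounds and their numbers:

compound 1, `COc1ccc(C2=Nc3c(C(C)(C)C)nn(CCCO)c3C(=O)NC2)cc1-c1ccc(F)cc1F`: in an ADME assay on microsomes from liver (Homo sapiens) for metabolic stability (on this read-out lower numbers stand for a shorter-lived compound and higher numbers for a longer-lived compound), compound 1 gives 2 h;
compound 2, `COc1ccc(-c2cc(C3=Nc4c(C(C)(C)C)nn(CCCO)c4C(=O)NC3)ccc2OC)c(OC)c1`: compound 2 gives 2 h;
compound 3, `COc1ccc(C2=Nc3c(C(C)(C)C)nn(CCCO)c3C(=O)NC2)cc1-c1ccccc1F`: compound 3 gives 0.8 h.

Compound 3 stands lowest of the three numbers: there is a 2.5-fold lower number from compound 1 to compound 3 (0.40 log units; beyond the scatter) and a 2.5-fold lower number from compound 2 to compound 3 (0.40 log units; beyond the scatter), whereas there is no change at the digits printed from compound 1 to compound 2 (within the scatter). Both steps leading into compound 3 are modest yet beyond the scatter, and both concern the group on the same aromatic carbon of the shared core.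

Compound 4, `COc1ccc(C2=Nc3c(C(C)(C)C)nn(CCCO)c3C(=O)NC2)cc1-c1cnc(N(C)C)cc1C`, is not yet measured in this assay. Its change from compound 3 is 6-(dimethylamino)-4-methylpyridin-3-yl in place of 2-fluorophenyl on an aromatic carbon. For the measured compounds named here, the steps that bear on this are a 2.5-fold lower number from compound 2 to compound 3 (0.40 log units; beyond the scatter) and a 2.5-fold lower number from compound 1 to compound 3 (0.40 log units; beyond the scatter), since each alters exactly that group; both were modest. Neither step involves the group that enters here, so the direction for compound 4 is open, and the measured numbers span only a modest range. A modest step, or none beyond the scatter, is therefore expected. Compound 4 is expected to give about 1.2 h in this assay, in the range 0.5 h to 3 h. That estimate corresponds to an expected step of a 1.5-fold higher number from compound 3 to compound 4 (0.18 log units; within the scatter).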

Compound 4, half-life: 0.7 h
Compound 4: the middle estimate sits 1.7-fold (0.23 log units) above what was measured; low and high end bracket the measured number.
By their numbers in this assay, from the lowest: compounds 4 and 3 (each within the scatter of the next); then compounds 1 and 2 (each within the scatter of the next).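

In this assay, the 6-(dimethylamino)-4-methylpyridin-3-yl group, the only one shown with a hetero atom in its aromatic ring, gives a 1.1-fold lower number from compound 3 to compound 4 (0.06 log units; within the scatter), so this read-out does not separate it from 2-fluorophenyl at this position, ortho to a methoxy group. The earlier compounds shown here allowed the reading that a second substituent on the incoming ring goes with the higher number, but compound 4 goes against it: its ring also carries two substituents, and yet the steps are a 2.9-fold lower number from compound 2 to compound 4 (0.46 log units; beyond the scatter) and a 2.9-fold lower number from compound 1 to compound 4 (0.46 log units; beyond the scatter). Nothing measured here explains why these groups fall where they do.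

The ring nitrogen, the dimethylamino group and the methyl group all enter together, so the compounds shown do not tell which of them, if any, bears on the half-life. From the compounds shown here alone, it remains open how an unsubstituted pyridine ring would read at this position, or a morpholine in place of the dimethylamino group.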